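Amide nitrogen swap: isoquinolinyl to methylpyrazinyl on compound 2

The source may report more compounds than this note shows. Statements on the series, on what has been measured and on what is new or still open speak of the compounds shown alone.

Measured so far:
compound 1 `COc1ccc(CCC(=O)N(c2nccc3ccccc23)[C@@H]2CCCNC2)cc1` gives 21 mL.min-1.g-1
compound 2 `O=C(N1CCC(c2ccccc2)CC1)N(c1nccc2ccccc12)[C@@H]1CCCNC1` gives 13.9 mL.min-1.g-1
compound 3 `Cc1ccc2c(N3CCN(C(=O)N(c4nccc5ccccc45)[C@@H]4CCCNC4)CC3)noc2c1` gives 12.9 mL.min-1.g-1

These three were run in an ADME assay on microsomes from liver (Homo sapiens) for metabolic stability; a lower number here means slower removal, a higher number faster removal of the compound. Compound 2 stands second highest of the three numbers; its nearest neighbour is compound 3, and its furthest is compound 1, yet both gaps lie within the usual scatter of this assay, so the three compounds cannot be told apart on these numbers. Among the compounds with values here, no step between two measured compounds that differ in only one place is available, so nothing in the set shows how a change on the amide-type nitrogen moves the read-out.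

The unmeasured compound 4 `Cc1nccnc1N(C(=O)N1CCC(c2ccccc2)CC1)[C@@H]1CCCNC1` differs from compound 2 as follows: 3-methylpyrazin-2-yl in place of isoquinolin-1-yl on an amide-type nitrogen. Within the data shown here, with no matching step in the measured set, the expectation rests only on the value of compound 2 in this assay, 13.9 mL.min-1.g-1, and on the sizes of the groups counted above. The step from compound 2 to compound 4 is expected to be small, a 1.5-fold lower number from compound 2 to compound 4 (0.19 log units; within the scatter), most likely a mild decrease but possibly none beyond the scatter. Compound 4 is estimated at 9 mL.min-1.g-1, within a range from 4 mL.min-1.g-1 to 20 mL.min-1.g-1.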

Compound 4, intrinsic clearance in microsomes: < 8 mL.min-1.g-1
Compound 4: a limit, no number; the forecaster's own chance of this, stated with the estimate: 5%; at least 1.1-fold (0.05 log units) between middle value and limit.
By their numbers in this assay, from the lowest: compounds 3, 2 and 1 (each within the scatter of the next). At a limit, below all of these: compound 4.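

In this assay compound 4 gives < 8 mL.min-1.g-1, which is a limit of the assay and not a number. This is the only one-place step shown in the series, and it reads an at least 1.7-fold lower number from compound 2 to compound 4 (0.23 log units; that floor lies within the scatter); on the amide-type nitrogen, 3-methylpyrazin-2-yl in place of isoquinolin-1-yl gives no sign of a higher read-out, though this floor alone does not establish a fall. The full size of the step cannot be read because compound 4 sits at the limit: the limit of < 8 mL.min-1.g-1 in this assay, at which 1 of the 4 values shown sits.

Which part of the swap carries the step stays open, and a pyrazin-2-yl group with an amine or a longer chain in place of the methyl would help to separate the contributions. On these data alone, whether the same swap behaves alike on the cores of compound 1 and compound 3 is also open.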